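Swapping furan-2-yl for vinyl on a carbonyl carbon

A few compounds are considered here, and "the series" means these few. Any claim that something is new, unique, unknown or untested is made for them only; others in the source may bear on it.

In a functional assay on MV4-11 cells (Homo sapiens) for cytotoxicity, read by MTT assay, with a stated time of 72 h (on this read-out higher numbers stand for weaker inhibition and lower numbers for stronger inhibition), compound 1 (`CCOC(=O)c1csc2nc(-c3ccc(NS(=O)(=O)c4ccc(C)cc4)cc3)cn12`) gives only a limit, > 20000 nM. Among the compounds with values here, compound 2 (`CCOC(=O)c1csc2nc(-c3ccc(NC(=O)c4ccco4)cc3)cn12`) gives 9920 nM, the only actual number so far. Compound 3 (`C=CC(=O)Nc1ccc(-c2cn3c(C(=O)OCC)csc3n2)cc1`) has vinyl in place of furan-2-yl on a carbonyl carbon. Within the data shown here, the one measured step bearing on this changes a group on the same nitrogen: an at least 2.0-fold lower number from compound 1 to compound 2 (0.30 log units; that floor lies within the scatter). It sets only a floor, so no step beyond the scatter is expected in this assay. The expected change is a 1.2-fold lower number from compound 2 to compound 3 (0.09 log units; within the scatter). For compound 3, the estimated value is 8000 nM, with an expected range of 2500 nM to 20000 nM.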

Compound 3, half-maximal inhibitory concentration: 2930 nM
Compound 3: the middle estimate sits 2.7-fold (0.44 log units) above what was measured; measured number inside the range.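

In this assay, the group on this carbonyl carbon now makes a difference beyond the scatter: vinyl in place of furan-2-yl gives a 3.4-fold lower number from compound 2 to compound 3 (0.53 log units; beyond the scatter). The earlier pair could not show this, since its floor lay within the scatter and it changed the whole group on the nitrogen, whereas here the amide stays in place. Replacing the sulfonyl group gives an at least 6.8-fold lower number from compound 1 to compound 3 (0.83 log units; beyond the scatter), which is only a floor set by a limit: the limit of > 20000 nM in this assay, at which 1 of the 3 values shown sits.

As far as these compounds go, how an ethyl group or a longer chain on this carbonyl carbon would compare with vinyl remains open. So does whether the double bond of vinyl matters at all.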